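The source may report more compounds than this note shows. Statements on the series, on what has been measured and on what is new or still open speak of the compounds shown alone.

Of the compounds shown here, two sharing a common chain have been measured in a functional assay on Umbilical vein for antagonist activity at B1 bradykinin receptor (Homo sapiens), using Schild analysis, with a stated time of 30 min; a higher number here means a more potent compound, by a factor of ten per unit of this negative logarithm, a lower number a less potent compound. Compound 1 `COc1cc(C)c(S(=O)(=O)N(C)CCOCC(=O)N2CCN(C3CCN(C4CC4)CC3)CC2)c(C)c1` is one of them, and in this assay compound 1 gives 8.5. Compound 2 `COc1ccc(S(=O)(=O)N(C)CCOCC(=O)N(C)Cc2ccc(C3=NCCN3)cc2)c(C)c1` differs from compound 1 in the group attached to the carbonyl end of the chain, and in this assay compound 2 gives 8.6. Compound 2 holds the higher of the two numbers, but its gap to compound 1 lies within the usual scatter, so the two cannot be ranked on this evidence. Compound 3 `CN(Cc1ccc(C2=NCCN2)cc1)C(=O)COCCN(C)S(=O)(=O)c1ccccc1C(F)(F)F` keeps everything in compound 2 except the aryl group attached to the sulfonyl sulfur: 2-(trifluoromethyl)phenyl in place of 4-methoxy-2-methylphenyl on a sulfonyl sulfur. Among the compounds with values here, no pair of measured compounds differs at that position, so there is no measured step for this exchange to draw on. Within the data shown here, with no such step available, the change is expected to cost little, at most a small loss that need not exceed the scatter, so the expected step is a number 0.30 log units lower from compound 2 to compound 3 (within the scatter). Compound 3 is therefore estimated at 8.3 in this assay, within a range from 7.6 to 9.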

Compound 3, negative logarithm of the antagonist equilibrium constant: 9.2
Estimate against measurement, compound 3: 0.90 log units below; measured number above the stated range.
By their numbers in this assay, from the lowest: compounds 1 and 2 (each within the scatter of the next); then compound 3.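

Within the data shown here, the exchange on the sulfonyl sulfur is not the neutral one that the earlier compounds left open: in this assay, 2-(trifluoromethyl)phenyl in place of 4-methoxy-2-methylphenyl gives a number 0.60 log units higher from compound 2 to compound 3 (beyond the scatter), so the aryl group at this place clearly bears on the number. The entering group has 0 hydrogen-bond acceptors and the leaving group has 1, so with this core a hydrogen-bond acceptor on the aryl group is not required, as compound 3 reaches 9.2 without one. Nothing measured here accounts for the direction or size of this step, so its cause remains unknown.

A single exchange cannot separate what the trifluoromethyl group contributes from what the loss of the methoxy and methyl groups contributes, and a plain phenyl group or a 2-methylphenyl group at this place would begin to divide the two. As far as these compounds go, it also remains open whether 2-(trifluoromethyl)phenyl gives a similar step when the carbonyl end of the chain carries the group found in compound 1.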